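Shrinking the Ring on an Amide Nitrogen

The source may report more compounds than this note shows. Statements on the series, on what has been measured and on what is new or still open speak of the compounds shown alone.

Measured so far in an assay on isolated protein for inhibition of endoplasmic reticulum aminopeptidase 2 (Homo sapiens); on this read-out lower numbers stand for stronger inhibition and higher numbers for weaker inhibition:
Compound 1 `CN(C(=O)c1cc(F)cc2cc(-c3ccc(Cl)cc3)oc12)C(C)(C)C(=O)O`: "not determined" (no result reported).
Compound 2 `O=C(NC1(C(=O)O)CCCCC1)c1cc(F)cc2cc(-c3ccc(Cl)cc3)oc12`: > 30000 nM.

Compound 2 stands at the limit of > 30000 nM in this assay, at which 1 of the 2 values shown sits, which is a limit of this assay rather than a number. Compound 3 `O=C(NC1(C(=O)O)CC1)c1cc(F)cc2cc(-c3ccc(Cl)cc3)oc12` differs from compound 2 by 1-carboxycyclopropyl in place of 1-carboxycyclohexyl on an amide-type nitrogen. For the measured compounds named here, no measured step of this kind is available, so the expected step from compound 2 to compound 3 is a step that the limit leaves unreadable from compound 2 to compound 3, in no clear direction beyond the scatter. Compound 3 is therefore expected near 40000 nM, between 8000 nM and 200000 nM, and most likely again reported only as a limit.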

Compound 3, half-maximal inhibitory concentration: > 30000 nM
Compound 3: no number, only a limit (the forecaster's own chance of this, stated with the estimate: 75%); the middle value does not contradict the limit.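

Compound 2 and compound 3 both end at a limit of the assay rather than a number, so no step between them can be read: the limit of > 30000 nM in this assay, at which 2 of the 3 values shown sit.

The compounds shown leave open whether 1-carboxycyclopropyl and 1-carboxycyclohexyl differ at all in this assay.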